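Swapping Bromo for Methoxy on a Fluorinated Core

This account rests on a few compounds, and the source may have more. Where it says the series, first, only, none or still open, it means among the compounds named here.

Compound 1 `Cn1ccc2c(Oc3ccc(NC(=O)c4cc5cccnc5n(-c5ccc(Br)cc5)c4=O)cc3)ccnc21` and compound 2 `COc1ccc(-n2c(=O)c(C(=O)Nc3ccc(Oc4ccnc5c4ccn5C)cc3)cc3cccnc32)cc1` differ in a single place: methoxy in place of bromo on an aromatic carbon. In a functional assay on HT-29 cells (Homo sapiens) for antiproliferative activity, read by MTT assay, with a stated time of 72 h (on this read-out lower numbers stand for stronger inhibition and higher numbers for weaker inhibition), compound 1 gives 690 nM, and compound 2 gives 2050 nM. That change produced a 3.0-fold higher number from compound 1 to compound 2 (0.47 log units; beyond the scatter), a weakening that is clear of the usual scatter.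

Compound 3 `Cn1ccc2c(Oc3ccc(NC(=O)c4cc5cccnc5n(-c5ccc(Br)cc5)c4=O)cc3F)ccnc21` shares the core of compound 1 but carries one further change: fluoro in place of hydrogen on an aromatic carbon. In this assay compound 3 gives 330 nM, and the step is a 2.1-fold lower number from compound 1 to compound 3 (0.32 log units; beyond the scatter). Compound 3 therefore stands lowest among the three measured numbers, with compound 2 furthest from it.

Compound 4 `COc1ccc(-n2c(=O)c(C(=O)Nc3ccc(Oc4ccnc5c4ccn5C)c(F)c3)cc3cccnc32)cc1` has not yet been measured in this assay. It differs from compound 3 exactly as compound 2 differs from compound 1: methoxy in place of bromo on an aromatic carbon. The surroundings of the change are described in the same words in both pairs, so this is the same change, now made on the core that carries fluoro in place of hydrogen. Within the data shown here, the only earlier example of this swap is the pair of compound 1 and compound 2; nothing shows whether the fluoro alters its effect.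

Because the step of a 3.0-fold higher number from compound 1 to compound 2 (0.47 log units; beyond the scatter) was measured on a core that differs only by fluoro in place of hydrogen on an aromatic carbon, the expected step here is a 3.0-fold higher number from compound 3 to compound 4 (0.48 log units; beyond the scatter). Compound 4 is estimated at 1000 nM in this assay, with a likely range from 450 nM to 2300 nM.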

Compound 4, half-maximal inhibitory concentration: 1290 nM
Beside the measured number, compound 4's estimate is 1.3-fold (0.11 log units) below it; the range from low to high includes it.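

In this assay, the swap of bromo for methoxy on the fluorinated core gives a 3.9-fold higher number from compound 3 to compound 4 (0.59 log units; beyond the scatter), and this step matches the one measured on the core without fluoro: the same change on two cores in this assay, a 3.0-fold higher number (0.47 log units; beyond the scatter) from compound 1 to compound 2 and a 3.9-fold higher number (0.59 log units; beyond the scatter) from compound 3 to compound 4, 1.3-fold (0.12 log units) apart, within the scatter of two such steps. The fluoro change, read this time on the methoxy pair, gives a 1.6-fold lower number from compound 2 to compound 4 (0.20 log units; within the scatter), which lies within the scatter on its own, yet it does not differ from the step seen on the bromo pair: the same change on two cores in this assay, a 2.1-fold lower number (0.32 log units; beyond the scatter) from compound 1 to compound 3 and a 1.6-fold lower number (0.20 log units; within the scatter) from compound 2 to compound 4, 1.3-fold (0.12 log units) apart, within the scatter of two such steps. Within these four compounds, then, the change from 4-bromophenyl to 4-methoxyphenyl carried from one core to the other with the same direction and a similar size, but this is a single transfer between two closely related cores and shows neither why the number moves nor whether the same would hold on a more distant core.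

The compounds shown leave open how other groups in the same place, such as chloro, an amine, a carboxylic acid or a longer chain like ethoxy, would read in this assay. They also leave open whether a group other than fluoro on the core, such as chloro or methyl, would leave the bromo to methoxy step just as unchanged.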